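Ethylamide in place of the acid on compound 2

The compounds below may be only part of what the source reports. "The series", "measured", "known", "first", "only" and "open" are said of these compounds alone.

Of the compounds shown here, three have been measured in a functional assay on the whole organism (strain CD1) for inhibition, with Mus musculus as the target, with stated times of 15 min and 20 min, at a dose of 10 mg/kg by the subcutaneous route; a higher number here means more inhibition at the dose given (going by the name of the read-out), a lower number less inhibition. Compound 1 `NC/C(=C\c1ccc(O)c(O)c1)C(=O)O` gives 50.1%. Compound 2 `N#C/C(=C\c1ccoc1)C(=O)O` gives 30.7%, the second highest of the three numbers; compound 1 stands above it beyond the scatter, and compound 3 `NC/C(=C\c1ccoc1)C(=O)O`, which gives -1.5%, is the furthest from it. Within the data shown here, the one step between compounds that differ in a single place is a number 32.2 percentage points lower from compound 2 to compound 3 (beyond the scatter), a large fall.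

Compound 4 `CCNC(=O)/C(C#N)=C/c1ccoc1` is not yet measured. It differs from compound 2 as follows: ethylamino in place of hydroxy on a carbonyl carbon. The place is the carbonyl carbon, whose other neighbour is a double-bonded chain carbon.

Among the measured compounds shown here, none of the measured steps bears on this change. For the measured compounds named here, the one measured step concerns the cyano group on the double-bonded chain carbon, whereas the change to compound 4 leaves the cyano group untouched and exchanges the hydroxy on the carbonyl carbon for ethylamino. There is therefore no measured guide to the direction of the step in this assay, and the expectation must rest on compound 2 alone.

Compound 4 is therefore expected to stay near compound 2, with the estimated step of a number 2.7 percentage points lower from compound 2 to compound 4 (within the scatter) taken as no more than the scatter allows. The estimate for compound 4 is 28%, with a range from -10% to 60%.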

Compound 4, a percentage reported as inhibition, in the whole organism at one dose (the size of the read-out at that dose, not a potency): 31%
The estimate for compound 4 lay 3 percentage points below the measured number; the range from low to high includes it.
By their numbers in this assay, from the lowest: compound 3; then compounds 2 and 4 (each within the scatter of the next); then compound 1.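

In this assay, ethylamino in place of hydroxy on the carbonyl carbon gives a number 0.3 percentage points higher from compound 2 to compound 4 (within the scatter), so with the nitrile and the shared core kept, the free carboxylic acid is not needed for a reading of this size at this dose. This sets the carbonyl carbon apart from the double-bonded chain carbon that carries the nitrile, where aminomethyl gave a number 32.2 percentage points lower from compound 2 to compound 3 (beyond the scatter): of the two places changed on compound 2, only the latter shows a step beyond the scatter. The data offer no measurement that would explain this difference between the two places.

Going by these compounds, it remains open whether the same holds for other groups on the carbonyl carbon, such as methylamino, dimethylamino, a longer chain on the amide nitrogen or an ethyl ester. Also open, on these data alone, is whether ethylamino would give a similar reading in the setting of compound 3, with aminomethyl in place of the nitrile, or on the core of compound 1, and how these compounds would compare at other doses.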